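Permeability series: aryl variation on the shared core

The source may report more compounds than this note shows. Statements on the series, on what has been measured and on what is new or still open speak of the compounds shown alone.

Among the measured compounds shown here, compound 3 `COc1cccc(CNCCCNc2ccnc3cc(Oc4ccc(F)cc4)ccc23)c1O` gives 317 10^-6 cm/s in an ADME assay for permeability, using PAMPA, with a stated time of 30 min, at pH 7.4 (a lower number here means that the compound crosses the layer more slowly, a higher number that the compound crosses the layer faster), the highest of the three numbers so far. Compound 1 `COc1cccc(CNCCCNc2ccnc3cc(-c4ccc(F)cc4)ccc23)c1O` gives 237 10^-6 cm/s, and the step is a 1.3-fold higher number from compound 1 to compound 3 (0.13 log units; within the scatter). Compound 2 `COc1cccc(CNCCCNc2ccnc3cc(Cc4cccc(C(F)(F)F)c4)ccc23)c1O` gives 23 10^-6 cm/s, with a 14-fold higher number from compound 2 to compound 3 (1.14 log units; beyond the scatter) and a 10-fold lower number from compound 1 to compound 2 (1.01 log units; beyond the scatter). Compound 4 `COc1cccc(CNCCCNc2ccnc3cc(-c4cccc5ccccc45)ccc23)c1O` differs from compound 3 as follows: naphthalen-1-yl in place of 4-fluorophenoxy on an aromatic carbon. For the measured compounds named here, two steps bear on this: the phenyl-to-phenoxy exchange stayed within the scatter, while only the benzyl of compound 2 moved the number. Naphthalen-1-yl, like the 4-fluorophenyl of compound 1, sits directly on the aromatic carbon. Compound 4 is therefore expected to stay within the scatter, a 1.6-fold lower number from compound 3 to compound 4 (0.20 log units; within the scatter). The estimate for compound 4 is 200 10^-6 cm/s, ranging from 90 10^-6 cm/s to 420 10^-6 cm/s.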

Compound 4, apparent permeability: 237 10^-6 cm/s
Estimate against measurement, compound 4: 1.2-fold (0.07 log units) below, within the range that was stated.
By their numbers in this assay, from the lowest: compound 2; then compounds 1, 4 and 3 (each within the scatter of the next).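

At this position, naphthalen-1-yl, with two aromatic rings of carbon only, gives a number in this assay that matches those of the single-ring groups: no change at the digits printed from compound 1 to compound 4 (within the scatter) and a 1.3-fold lower number from compound 3 to compound 4 (0.13 log units; within the scatter). Compound 2 stays apart, a 10-fold higher number from compound 2 to compound 4 (1.01 log units; beyond the scatter), so among these four compounds only the 3-(trifluoromethyl)benzyl group stands away from the others. Nothing available explains this difference.

Still open, as far as these compounds go, is whether the low number of compound 2 goes with the benzyl link or with the trifluoromethyl, which change together here; an unsubstituted benzyl would separate them. Also open, from the compounds shown here alone, is how an amine or a carboxylic acid on the aryl ring would read.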